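Saturated hexyl chain replacing a hexynyl chain on the sulfonamide aryl

The source may report more compounds than this note shows. Statements on the series, on what has been measured and on what is new or still open speak of the compounds shown alone.

Of the compounds shown here, two sharing one core have been measured in a functional assay on A-375 cells (Homo sapiens) for antiproliferative activity, read by trypan blue exclusion, with a stated time of 48 h, tested at 1 uM; a higher number here means a weaker effect of the compound at the concentration tested, a lower number a stronger effect. Compound 1, with the structure `CCCCC#Cc1ccc(S(=O)(=O)Nc2cccc(-c3csc(NC(C)=O)n3)c2)cc1`, gives 73.2%. Compound 2, with the structure `C#Cc1cccc(S(=O)(=O)Nc2cccc(-c3csc(NC(C)=O)n3)c2)c1`, gives 74.3%. Compound 1 holds the lower of the two numbers, but the distance to compound 2 lies within the scatter of this assay, so the two cannot be told apart on these data.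

The compound still to be measured is compound 3, with the structure `CCCCCCc1ccc(S(=O)(=O)Nc2cccc(-c3csc(NC(C)=O)n3)c2)cc1`. It differs from compound 1 in one place: hexyl in place of hex-1-yn-1-yl on an aromatic carbon. The change sits on an aromatic carbon of a six-membered aromatic ring of carbon only, para to a large group, and keeps the count of heavy atoms the same while removing the triple bond outside aromatic rings.

Going by the values given here, no measured pair shows what such a change does in this assay. Among the compounds with values here, with a single pair of similar numbers as the only guide, the step from compound 1 to compound 3 is expected to be small, with no direction beyond the scatter, giving a number 1.2 percentage points lower from compound 1 to compound 3 (within the scatter). Compound 3 is therefore estimated at 72%, within a range from 55% to 88%.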

Compound 3, a percentage reported as activity, at one concentration (the size of the read-out at that concentration, not a potency): 49.9%
Estimate against measurement, compound 3: 22.1 percentage points above; the measured number lies below the stated range.
By their numbers in this assay, from the lowest: compound 3; then compounds 1 and 2 (each within the scatter of the next).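

Replacing hex-1-yn-1-yl with hexyl gives a number 23.3 percentage points lower from compound 1 to compound 3 (beyond the scatter) in this assay, so at this place on the ring the chain is more than a simple six-carbon spacer: the heavy atom count stays the same and only the triple bond outside aromatic rings goes, yet the compound has a clearly stronger effect at the concentration tested. Compounds 1 and 2 could not reveal this, as they differ in more than one place and their numbers lie within the scatter of each other, which gave no sign that this position would respond to a change in the chain. Nothing available explains why removing the triple bond has this effect, so the step remains an observation without a known cause.

The compounds shown leave open whether the trend would continue with a shorter chain such as butyl, a longer chain such as octyl, or a hexyl chain ending in an amine. They also leave open whether the stronger effect would hold at other concentrations, as a reading at one concentration gives only the size of the effect at that concentration.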